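The source may hold more compounds than are shown below. What is called first, only, known or untested is meant among the compounds shown, and "the series" means these compounds.

Measured compounds:
compound 1, `CCCCCCCCCCNc1ccc(O)cc1`: 66%
compound 2, `CCCCCCCCCCCC(=O)Nc1ccc(O)cc1`: 6%

Two compounds share the core seen in compound 1. In a functional assay on HL-60 cells (Homo sapiens) for inhibition, with a stated time of 72 h, tested at 4 uM (on this read-out higher numbers stand for more inhibition at the one concentration tested (going by the name of the read-out) and lower numbers for less inhibition), compound 1 gives 66%, and in this assay compound 2 gives 6%. Compound 2 stands lowest of the two numbers; the nearest number, that of compound 1, lies higher, a gap beyond the scatter. No step between compounds differing in one place is recorded, so nothing can be said of the cause of that gap.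

Compound 3, `CCCCCCCCCC(=O)Nc1ccc(O)cc1`, is not yet measured. It differs from compound 2 as follows: hydrogen in place of ethyl on a saturated chain carbon, nine bonds along the chain from a carbonyl carbon. Within the data shown here, with no recorded step of this kind, the expected size of the step in this assay is small, upward if anything, likely within the scatter. Compound 3 is estimated at 12%, with a range from 0% to 35%, a step from compound 2 of a number 6 percentage points higher from compound 2 to compound 3 (within the scatter).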

Compound 3, a percentage reported as inhibition, at one concentration (the size of the read-out at that concentration, not a potency): 6%
Compound 3: middle estimate off by 6 percentage points, on the high side; measured number inside the range.
By their numbers in this assay, from the lowest: compounds 2 and 3 (each within the scatter of the next); then compound 1.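

In this assay, among these compounds, hydrogen in place of ethyl on a saturated chain carbon, nine bonds along the chain from a carbonyl carbon, gives no change at the digits printed from compound 2 to compound 3 (within the scatter), the first step that can be read at this position. Compound 3 has the carbonyl that compound 1 lacks, and compound 3 gives 6% while compound 1 gives 66%, so the low number of compound 2 is not confined to the longer of the two acyl chains. Nothing measured here explains why this change leaves the number in place.

As far as these compounds go, whether the same change would leave the number of compound 1 in place remains open. So does what an amine or a carboxylic acid on this chain, or a longer chain, would give.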